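A Single Number and the Step to Compound 4

The compounds below may be only part of what the source reports. "The series", "measured", "known", "first", "only" and "open" are said of these compounds alone.

In a functional assay on MDA-MB-231 cells (Homo sapiens) for inhibition, read by CCK-8 assay, with a stated time of 48 h (on this read-out lower numbers stand for stronger inhibition of growth and higher numbers for weaker inhibition of growth), compound 1 (`Cc1ccccc1Nc1nc(NC2CCCCC2)ncc1Cl`) gives > 100000 nM as a limit of the assay, not a number. Compound 2 (`Cc1ccccc1Nc1nc(NCc2ccccc2)ncc1Cl`) gives > 100000 nM as a limit too. The record so far is marked by the limit of > 100000 nM in this assay, at which 2 of the 3 values shown sit, and little else. For the measured compounds named here, compound 3 (`CN1CCN(c2ccc(Nc3ncc(Cl)c(NCc4ccc(C(F)(F)F)cc4)n3)nc2)CC1`) gives 19100 nM and is the only compound with a true number in this assay so far.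

Compound 4 (`Cc1ccc(Nc2nc(Nc3ccc(N4CCN(C)CC4)cn3)ncc2Cl)cc1`) differs from compound 3 by 4-methylphenyl in place of 4-(trifluoromethyl)benzyl on a nitrogen on an aromatic ring and keeps the rest of its structure. Going by the values given here, only one measured step also changes a group on such a nitrogen, namely a step that the two limits leave unreadable from compound 1 to compound 2 and it offers no size to carry over. With no readable step to draw on, the expectation rests on compound 3 at 19100 nM and sets no direction. The step of a 1.3-fold lower number from compound 3 to compound 4 (0.10 log units; within the scatter) is therefore expected to stay within the usual scatter, though with wide uncertainty. Compound 4 is estimated at 15000 nM (expected range 3000 nM to 60000 nM).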

Compound 4, concentration for 50% growth inhibition: 4030 nM
Estimate against measurement, compound 4: 3.7-fold (0.57 log units) above; measured number inside the range.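

For the compounds shown here, replacing 4-(trifluoromethyl)benzyl with 4-methylphenyl on a nitrogen on an aromatic ring gives a 4.7-fold lower number from compound 3 to compound 4 (0.68 log units; beyond the scatter) in this assay, the first step of readable size at this kind of place, and it lies beyond the scatter. The earlier step at such a nitrogen, between two limits, could not be read, whereas this one shows that the group there can shift the number while the rest of the structure stays the same. Nothing given here explains the size of this step.

This one step alters the methyl or trifluoromethyl group and the link from the ring to the nitrogen together, leaving open which of the two changes carries the difference. Also open, going by these compounds, is how a carboxylic acid, an amine or a longer chain on that nitrogen would read in this assay.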